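Cyano for trifluoromethyl on the benzyl ring

The compounds below may be only part of what the source reports. "The series", "measured", "known", "first", "only" and "open" are said of these compounds alone.

Measured so far:
compound 1 `Cc1ccccc1-n1cc(CNC(=O)c2cccc3c2cnn3C(C)C)nn1`, which in a functional assay on PC-3 cells (Homo sapiens) for inhibition, read by MTT assay, with a stated time of 72 h (a lower number here means a stronger inhibitor, a higher number a weaker inhibitor), gives 19200 nM
compound 2 `CC(C)n1ncc2c(C(=O)NCc3cn(Cc4ccc(C(F)(F)F)cc4)nn3)cccc21`, which in this assay gives 23900 nM

Compound 2 holds the higher of the two numbers, but its gap to compound 1 lies within the scatter, so the pair cannot be ordered. Compound 3 `CC(C)n1ncc2c(C(=O)NCc3cn(Cc4ccc(C#N)cc4)nn3)cccc21` differs from compound 2 by cyano in place of trifluoromethyl on an aromatic carbon. Among the measured compounds shown here, no measured pair shows this change, so no step size can be read from the series. In this assay no step beyond the scatter is expected in either direction. Compound 3 is therefore expected at 22000 nM, between 8000 nM and 60000 nM. The expected step is a 1.1-fold lower number from compound 2 to compound 3 (0.04 log units; within the scatter).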

Compound 3, half-maximal inhibitory concentration: 18200 nM
Estimate against measurement, compound 3: 1.2-fold (0.08 log units) above; the measured number falls inside the stated range.
By their numbers in this assay, from the lowest: compounds 3, 1 and 2 (each within the scatter of the next).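

In this assay, cyano in place of trifluoromethyl, para to a large group, gives a 1.3-fold lower number from compound 2 to compound 3 (0.12 log units; within the scatter) and so does not separate the two compounds at this position. The aromatic nitrogen substituent shows the same picture: 4-cyanobenzyl in place of 2-methylphenyl gives a 1.1-fold lower number from compound 1 to compound 3 (0.02 log units; within the scatter) and leaves the numbers indistinguishable. No measurement at hand explains these results.

From the compounds shown here alone, whether an amine or a carboxylic acid at this place on the ring would give a step beyond the scatter remains open. The compounds shown also leave open whether any substituent here affects the number at all.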